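The compounds below may be only part of what the source reports. "The series", "measured", "known", "first", "only" and "open" are said of these compounds alone.

Series notes. Compound 1 `COc1ccc(S(=O)(=O)N2CCc3cccc(-c4cccnc4)c32)cc1` and compound 2 `COc1ccc(S(=O)(=O)N2CCc3cccc(-c4c(F)c(F)c(F)c(F)c4F)c32)cc1` share one core and differ only in the group attached to it. Within the data shown here, in a functional assay on HT-29 cells (Homo sapiens) for inhibition, with a stated time of 72 h (a lower number here means a stronger inhibitor, a higher number a weaker inhibitor), compound 1 gives 76.3 nM, the lowest of the two numbers known so far. Compound 2 gives 3900 nM, far higher and beyond the scatter. Compound 3 `COc1ccc(S(=O)(=O)N2CCc3cccc(-c4ccncc4)c32)cc1` is not yet measured; it differs from compound 1 by pyridin-4-yl in place of pyridin-3-yl on an aromatic carbon. Among the measured compounds shown here, no measured pair shows this change, so the step is judged from the change alone: the expected step is a 1.4-fold higher number from compound 1 to compound 3 (0.16 log units; within the scatter), toward a slightly weaker inhibitor but likely within the scatter. Compound 3 is therefore estimated at 110 nM, within 35 nM to 400 nM.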

Compound 3, half-maximal inhibitory concentration: 87.5 nM
Beside the measured number, compound 3's estimate is 1.3-fold (0.10 log units) above it; measured number inside the range.
By their numbers in this assay, from the lowest: compounds 1 and 3 (each within the scatter of the next); then compound 2.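

Replacing pyridin-3-yl with pyridin-4-yl on this aromatic carbon gives a 1.1-fold higher number from compound 1 to compound 3 (0.06 log units; within the scatter) in this assay. This position therefore tolerates the change between these two pyridine isomers, and this assay does not separate them. No available measurement accounts for this result.

Still open, going by these compounds, is whether a plain phenyl ring would track with compounds 1 and 3 or with compound 2. Also open, on these data alone, is how pyridin-2-yl, or an amine or a carboxylic acid on the pyridine ring, would read in this assay.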